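Piperidine amide replacing fluorobenzyl amide in inactive series

A few compounds are considered here, and "the series" means these few. Any claim that something is new, unique, unknown or untested is made for them only; others in the source may bear on it.

Measured compounds:
compound 1, `CC1CCN(C(=O)CCNC(=O)c2ccc(S(C)(=O)=O)c([N+](=O)[O-])c2)CC1`, > 60000 nM
compound 2, `CS(=O)(=O)c1ccc(C(=O)NCCCC(=O)N2CCC(c3ccccc3)CC2)cc1[N+](=O)[O-]`, > 60000 nM
compound 3, `CN(Cc1cccc(F)c1)C(=O)CCCNC(=O)c1ccc(S(C)(=O)=O)c([N+](=O)[O-])c1`, > 60000 nM

In an assay on isolated protein for inhibition of vitamin D3 receptor (Homo sapiens), read by fluorescence polarization (on this read-out lower numbers stand for stronger inhibition and higher numbers for weaker inhibition), compound 3 reaches only the limit of the assay, > 60000 nM, and no number was obtained for it. The same holds for compound 1, whose result is the limit > 60000 nM. Compound 2 likewise gives only the limit > 60000 nM. All three values therefore sit at the limit of > 60000 nM in this assay, at which 3 of the 3 values shown sit, so no order among them can be read.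

Compound 4, `CS(=O)(=O)c1ccc(C(=O)NCCCC(=O)N2CCCCC2)cc1[N+](=O)[O-]`, has not yet been measured. It differs from compound 3 as follows: piperidin-1-yl in place of (3-fluorobenzyl)(methyl)amino on a carbonyl carbon. Since compound 3 sits at the limit > 60000 nM, and compound 1 and compound 2, which also carry saturated ring amides, sit there too, no step beyond the scatter is expected from compound 3 to compound 4 in this assay; the expected step is a step that the limit leaves unreadable from compound 3 to compound 4. Compound 4 is expected to give 100000 nM in this assay, within 30000 nM to 500000 nM, most likely reported again only as a limit.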

Compound 4, half-maximal inhibitory concentration: > 60000 nM
Compound 4 ended at the assay's limit (the forecaster's own chance of this, stated with the estimate: 90%); the middle value is on the limit's open side.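

In this assay, within the data shown here, compound 4 gives > 60000 nM, a limit and not a number, so no step from compound 1, compound 2 or compound 3 to compound 4 can be read: the limit of > 60000 nM in this assay, at which 4 of the 4 values shown sit. The compounds shown leave open which amide group, if any, would give a measurable value on the shared core.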